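The source may report more compounds than this note shows. Statements on the series, on what has been measured and on what is new or still open speak of the compounds shown alone.

Of the compounds shown here, three have been tested in a functional assay on the whole organism (Pleural cavity) for inhibition, with Rattus norvegicus as the target, at a dose of 25 mg/kg; a higher number here means more inhibition at the dose given (going by the name of the read-out), a lower number less inhibition. Compound 1 `CC1(C)C(=O)N(c2ccc(Cl)cc2Cl)c2ncccc21` gives 8% there, compound 2 `CC1(C)C(=O)N(c2ccccc2Cl)c2ncccc21` gives 3%, and compound 3 `CC1(C)C(=O)N(Cc2ccccc2)c2ncccc21` gives 12%. The difference between the cores of compound 2 and compound 3 is not broken down here. Compound 4 `CC1(C)C(=O)N(Cc2ccc(Cl)cc2)c2ncccc21` has not yet been measured; it differs from compound 3 by chloro in place of hydrogen on an aromatic carbon. A change of the same kind, not the same, links compound 2 to compound 1, (chloro in place of hydrogen on an aromatic carbon), where the place is additionally meta to a chloro group; that change gave a number 5 percentage points higher from compound 2 to compound 1 (within the scatter). Because the step of a number 5 percentage points higher from compound 2 to compound 1 (within the scatter) was small, the step of a number 3 percentage points higher from compound 3 to compound 4 (within the scatter) is expected to be small as well. Compound 4 is therefore estimated at 15%, expected to lie between 4% and 27%.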

Compound 4, a percentage reported as inhibition, in the whole organism at one dose (the size of the read-out at that dose, not a potency): 0%
The estimate for compound 4 lay 15 percentage points above the measured number, and the stated range ends above it.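

In this assay, chloro in place of hydrogen on an aromatic carbon did not carry over from one core to the other: the same change on two cores in this assay, a number 5 percentage points higher (within the scatter) from compound 2 to compound 1 and a number 12 percentage points lower (beyond the scatter) from compound 3 to compound 4, 17 percentage points apart, beyond the scatter of two such steps. The new step, a number 12 percentage points lower from compound 3 to compound 4 (beyond the scatter), places the chloro para to a large group, and its size and direction could not have been read from the earlier step. Among the compounds shown here, this does not show the reason, as the two pairs differ in both core and the place of the chloro, and each core offers only one pair.

The compounds shown leave open how an amine or a carboxylic acid at that aromatic carbon would behave in this assay. They also leave open whether a longer chain on the ring nitrogen would change the outcome.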